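Ring swap on the sulfonamide side chain: oxetane to oxolane

A few compounds are considered here, and "the series" means these few. Any claim that something is new, unique, unknown or untested is made for them only; others in the source may bear on it.

Measured so far in an ADME assay on MDCKII-LE cells (Canis lupus familiaris) for permeability, read by transwell migration, in the apical to basolateral direction; on this read-out lower numbers stand for lower permeability and higher numbers for higher permeability:
- compound 1 `NC(=O)[C@@H](CCC(F)(F)F)N(CC1COC1)S(=O)(=O)c1ccc(Cl)cc1` gives 25.4 10^-6 cm/s
- compound 2 `NC(=O)[C@@H](CCC(F)(F)F)N(CC1CCCC1)S(=O)(=O)c1ccc(Cl)cc1` gives 6.01 10^-6 cm/s

For the measured compounds named here, compound 1 stands highest of the two numbers; its nearest neighbour is compound 2, and the step of a 4.2-fold lower number from compound 1 to compound 2 (0.63 log units; beyond the scatter) is the only measured step in the set.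

The next compound is compound 3 `NC(=O)[C@@H](CCC(F)(F)F)N(C[C@H]1CCOC1)S(=O)(=O)c1ccc(Cl)cc1`. Its difference from compound 1 is oxolan-3-yl in place of oxetan-3-yl on a saturated chain carbon bound to a sulfonamide nitrogen. Going by the values given here, the measured step that bears on it is the one from compound 1 to compound 2, where cyclopentyl replaced oxetan-3-yl at the same place; that step was a 4.2-fold lower number from compound 1 to compound 2 (0.63 log units; beyond the scatter). The change to compound 3 keeps the ring oxygen and adds one ring carbon, so it sits between the two measured structures. Among the compounds with values here, a step in the same direction, but smaller than the one to compound 2, is therefore expected in this assay. For compound 3 the estimated step is a 1.8-fold lower number from compound 1 to compound 3 (0.26 log units; within the scatter), because the measured step of a 4.2-fold lower number from compound 1 to compound 2 (0.63 log units; beyond the scatter) points downward. Compound 3 is expected to give about 14 10^-6 cm/s, with a range from 7 10^-6 cm/s to 28 10^-6 cm/s.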

Compound 3, apparent permeability: 21.7 10^-6 cm/s
Beside the measured number, compound 3's estimate is 1.6-fold (0.19 log units) below it, within the range that was stated.
By their numbers in this assay, from the lowest: compound 2; then compounds 3 and 1 (each within the scatter of the next).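

In this assay, moving from the four-membered to the five-membered ring at this place, on a saturated chain carbon bound to a sulfonamide nitrogen, gives a 1.2-fold lower number from compound 1 to compound 3 (0.07 log units; within the scatter), so this ring enlargement with the ring oxygen kept does not separate the two compounds. At equal ring size, the comparison with the all-carbon ring gives a 3.6-fold higher number from compound 2 to compound 3 (0.56 log units; beyond the scatter); among these three compounds, the only step-down beyond the scatter therefore goes with loss of the ring oxygen, and ring size alone does not account for it. No supporting measurement is available to explain why the ring oxygen and this read-out go together here.

Still open, as far as these compounds go, is whether the trend holds for a larger oxygen ring such as oxan-4-yl, for an open-chain ether such as 2-methoxyethyl, or for a ring amine such as pyrrolidin-3-yl at the same place. From the compounds shown here alone, the opposite configuration at the oxolan-3-yl stereocentre is also open, so any dependence of the number on that centre remains unknown.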